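The source may report more compounds than this note shows. Statements on the series, on what has been measured and on what is new or still open speak of the compounds shown alone.

In a functional assay on CHO-K1 cells for antagonist activity at C-X-C chemokine receptor type 3 (Homo sapiens), read by FLIPR, with a stated time of 10 min (a higher number here means a weaker inhibitor, a lower number a stronger inhibitor), compound 2 `COc1ccc(-c2nc(C(F)(F)F)sc2N2CCN(C(=O)Cn3cnc4cccnc43)[C@H](C)C2)cc1` gives 13 nM, the lowest of the two numbers in hand. Compound 1 `O=C(Cn1cnc2cccnc21)N1CCN(c2scnc2-c2nc3ccccc3[nH]2)CC1` gives 30 nM in this assay, a higher number that lies beyond the scatter. Compound 3 `CCCc1ncc(-c2nc(C(F)(F)F)sc2N2CCN(C(=O)Cn3cnc4cccnc43)[C@H](C)C2)cn1` differs from compound 2 by 2-propylpyrimidin-5-yl in place of 4-methoxyphenyl on an aromatic carbon. Among the compounds with values here, no measured pair shows this change, so its size is unknown. The step is expected to be a 1.2-fold higher number from compound 2 to compound 3 (0.06 log units; within the scatter), of a size that stays within the scatter in either direction. The estimate for compound 3 in this assay is 15 nM, with a range from 5 nM to 50 nM.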

Compound 3, half-maximal inhibitory concentration: 3.3 nM
Beside the measured number, compound 3's estimate is 4.5-fold (0.66 log units) above it, outside the stated range (below it).
By their numbers in this assay, from the lowest: compound 3; then compound 2; then compound 1.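

At this aromatic carbon of the five-membered ring, the aryl group can be exchanged with a clear gain: 2-propylpyrimidin-5-yl in place of 4-methoxyphenyl gives a 3.9-fold lower number from compound 2 to compound 3 (0.60 log units; beyond the scatter) in this assay. A six-membered aromatic ring with 2 hetero atoms is thus accepted here, and it gives the lower number. Nothing measured here accounts for this step.

From the compounds shown here alone, the ring and the propyl chain change together, so the share of each in the step remains open. A 4-propylphenyl or 2-methoxypyrimidin-5-yl group at this carbon would separate them.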